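The source may report more compounds than this note shows. Statements on the series, on what has been measured and on what is new or still open speak of the compounds shown alone.

As far as these compounds go, the study gathers three measured compounds and one whose result is still open, all examined in an assay on CHO cells for displacement of a labelled ligand from adenosine receptor A2b (Homo sapiens), read by scintillation counting, with a stated time of 60 min; a lower number here means a stronger inhibitor, a higher number a weaker inhibitor. Compound 1 `COCCCNC(=O)COc1ccc2c(c1)c(CCc1ccccc1)c(-c1ccc(F)cc1F)c(=O)n2C` gives 677 nM in this assay. Compound 2 `CC[C@H](NC(=O)COc1ccc2[nH]c(=O)c(-c3nccs3)c(CCc3ccccc3)c2c1)c1ccccc1` gives 20 nM in this assay. Compound 3 `CS(=O)(=O)c1c(CCc2ccccc2)c2cc(OCC(=O)NCC3CC3)ccc2[nH]c1=O` gives > 10000 nM in this assay, and that figure is a limit of the assay rather than a measured number. In other words, compound 3 stands at the limit of > 10000 nM in this assay, at which 1 of the 3 values shown sits, so its true strength is not known, only that it falls on the weak side of that boundary.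

Compound 4 `CN(Cc1ccc(Cl)c(Cl)c1)C(=O)COc1ccc2[nH]c(=O)c(S(C)(=O)=O)c(CCc3ccccc3)c2c1` is the next compound and shares the core of compound 3. Among the measured compounds shown here, the single change is (3,4-dichlorobenzyl)(methyl)amino in place of (cyclopropylmethyl)amino on a carbonyl carbon. For the measured compounds named here, no measured pair in this set differs by exactly this change, so the size and direction of the step can only be estimated from the compounds at hand. Compound 2, which carries a larger amide substituent with an aromatic ring, gives 20 nM, but compound 2 also differs from compound 3 elsewhere, so it cannot settle the question. For compound 4 the expected value in this assay is 7000 nM, with a likely range from 1500 nM to 30000 nM. This estimate means a step of an at least 1.4-fold lower number from compound 3 to compound 4 (0.15 log units; that floor lies within the scatter), and a further limit reading is expected to be a real possibility.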

Compound 4, inhibition constant: 710 nM
Compound 4: the middle estimate sits 9.9-fold (0.99 log units) above what was measured; measured number below the stated range.
By their numbers in this assay, from the lowest: compound 2; then compounds 1 and 4 (each within the scatter of the next). At a limit, above all of these: compound 3.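

In this assay, putting (3,4-dichlorobenzyl)(methyl)amino in place of (cyclopropylmethyl)amino on a carbonyl carbon gives an at least 14-fold lower number from compound 3 to compound 4 (1.14 log units; beyond the scatter). This is only the smallest size the step can have, because the value of compound 3 is a limit and not a number: the limit of > 10000 nM in this assay, at which 1 of the 4 values shown sits. Among the compounds shown here, the earlier compounds offered no pair differing in one place, so this is the first direct sign that, with the rest of the molecule held fixed, the group on this carbonyl carbon can decide whether binding is readable in this assay at all.

The change does several things at once, since a three-membered ring leaves, an aromatic ring and chlorine atoms enter, and the amide hydrogen is lost, so the compounds shown cannot say which of these parts carries the step. A plain benzylamino group with no chlorine would test the aromatic ring alone, and a (cyclopropylmethyl)(methyl)amino group would test the loss of the amide hydrogen alone.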